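Moving the Chlorine on a Benzyl Group

The source may hold more compounds than are shown below. What is called first, only, known or untested is meant among the compounds shown, and "the series" means these compounds.

In a functional assay on NCI-H460 cells (Homo sapiens) for cytotoxicity, read by MTT assay, with a stated time of 72 h (a higher number here means a weaker inhibitor, a lower number a stronger inhibitor), compound 1 `CC1CCN(Cc2ccc3nc(NC(=O)N/N=C/c4cn(Cc5cccc(Cl)c5)c5ccccc45)sc3c2)CC1` gives 280 nM and compound 2 `CN(C)Cc1ccc2nc(NC(=O)N/N=C/c3cn(Cc4ccc(Cl)cc4)c4ccccc34)sc2c1` gives 290 nM as the half-maximal inhibitory concentration. These two numbers lie within the usual scatter of each other, so compound 2 stands level with compound 1 on the data so far. Compound 3 `CN(C)Cc1ccc2nc(NC(=O)N/N=C/c3cn(Cc4cccc(Cl)c4)c4ccccc34)sc2c1` is compound 2 with one change: 3-chlorophenyl in place of 4-chlorophenyl on a saturated chain carbon bound to an aromatic nitrogen, which also reads as 4-chlorobenzyl to 3-chlorobenzyl. The atoms stay the same and are only joined differently. For the measured compounds named here, no measured pair shows what this change does, so the data favour neither direction. An expected step of a 1.0-fold lower number from compound 2 to compound 3 (0.02 log units; within the scatter) stays within the scatter. Compound 3 is estimated at 280 nM with an expected range of 120 nM to 650 nM in this test.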

Compound 3, half-maximal inhibitory concentration: 420 nM
Compound 3: middle estimate off by 1.5-fold (0.18 log units), on the low side, within the range that was stated.
By their numbers in this assay, from the lowest: compounds 1, 2 and 3 (each within the scatter of the next).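

The first one-place comparisons show that in this assay the placement of the chlorine on this benzyl group makes no clear difference: going from 4-chlorobenzyl to 3-chlorobenzyl gives (a 1.4-fold higher number from compound 2 to compound 3 (0.16 log units; within the scatter)), which cannot be told apart from repeat-measurement noise. The amine end behaves alike, as dimethylamino in place of 4-methylpiperidin-1-yl on a saturated chain carbon bound to an aromatic carbon gives (a 1.5-fold higher number from compound 1 to compound 3 (0.18 log units; within the scatter)), again within the scatter. No measurement bears on why either change acts as it does.

These compounds leave open how a benzyl group with no chlorine, or with a methoxy group in place of the chlorine, would read in this assay. They also leave open whether a morpholin-4-yl group at the amine end would stay level with dimethylamino.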